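Swapping the Amide Tail of Compound 1

The compounds below may be only part of what the source reports. "The series", "measured", "known", "first", "only" and "open" are said of these compounds alone.

Compound 1, with the structure `CC(C)C[C@H](NC(=O)[C@]1(Cc2ccccc2)CCN1C(=O)OCc1ccccc1)C(N)=O`, was tested in an ADME assay on HELF cells (Homo sapiens) for cytotoxicity, with a stated time of 3 days (on this read-out lower numbers stand for higher toxicity in this test and higher numbers for lower toxicity in this test), where compound 1 gives 100000 nM. Two related compounds were run through this assay as well. Compound 2, with the structure `NC(=O)[C@H](CCC(=O)O)NC(=O)C1(Cc2ccccc2)CCN1C(=O)OCc1ccccc1`, reaches only a limit of the assay, reported as > 100000 nM. Compound 3, with the structure `C[C@H](NC(=O)[C@]1(Cc2ccccc2)CCN1S(=O)(=O)c1ccc2ccccc2c1)C(N)=O`, likewise reaches only a limit, reported as > 100000 nM. Taken together, the three results are shaped by the limit of > 100000 nM in this assay, at which 2 of the 3 values shown sit, which leaves compound 1 as the only compound with an actual number, sitting at the top of what this assay can report.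

Compound 4, with the structure `CC(C)CNC(=O)[C@H](C)NC(=O)[C@]1(Cc2ccccc2)CCN1C(=O)OCc1ccccc1`, has not yet been tested. It differs from compound 1 in a single place: 1-(isobutylcarbamoyl)ethyl in place of 1-carbamoyl-3-methylbutyl on an amide-type nitrogen. For the measured compounds named here, no measured pair of compounds shows how a change of this kind moves the read-out, so the expectation rests only on where compound 1 stands. Compound 4 is expected to show a step of no change at the digits printed from compound 1 to compound 4 (within the scatter), that is, none beyond the usual scatter. Compound 4 is therefore estimated at 100000 nM, with a likely range from 50000 nM to 200000 nM, and a fair chance that this assay again reports only a limit rather than a number.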

Compound 4, minimum cytotoxic concentration: > 100000 nM
Compound 4: only a limit was reported; the forecaster's own chance of this, stated with the estimate: 55%; the middle value lies on the limit itself.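

In this assay compound 4 gives > 100000 nM, which is a limit of the assay and not a number. Putting 1-(isobutylcarbamoyl)ethyl in place of 1-carbamoyl-3-methylbutyl on this amide-type nitrogen gives the only step shown for this position, and it reads as a number no lower from compound 1 to compound 4 (the limit leaves the size open), so this change brought no sign of higher toxicity in this test. The size of the step cannot be read because the results pile up at one end of the scale: the limit of > 100000 nM in this assay, at which 3 of the 4 values shown sit.

The compounds shown leave open whether a different group at this place, such as a tail ending in an amine or a longer alkyl chain, would give a real number lower than that of compound 1. They also leave open the true value of compound 4, which could be settled only by a test that reaches higher concentrations.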